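This account rests on a few compounds, and the source may have more. Where it says the series, first, only, none or still open, it means among the compounds named here.

Among the measured compounds shown here, compound 2 `CC(C)n1nc(-c2ccnc3[nH]c(C4CCN(CC(=O)N(C)C)CC4)cc23)ccc1=O` is the only compound of this pair for which a number rather than a limit is available in a physicochemical assay for solubility, in phosphate buffer, at pH 7.4; a higher number here means a more soluble compound, a lower number a less soluble compound: compound 2 gives 11000 nM. Compound 1 `CN(C)C(=O)CN1CCC(c2cc3c(-c4ccc(=O)n(C5CCC5)c4)ccnc3[nH]2)CC1` sits at the limit of this assay, giving > 1000000 nM, a limit at which one of the two values shown stands (the limit of > 1000000 nM in this assay, at which 1 of the 2 values shown sits). Compound 3 `CC(C)n1cc(-c2ccnc3[nH]c(C4CCN(CC(=O)N(C)C)CC4)cc23)ccc1=O` has not yet been measured. It differs from compound 2 by a group of 10 heavy atoms (8 carbon, 1 nitrogen, 1 oxygen; one six-membered aromatic ring with 1 hetero atom) in place of a group of 10 heavy atoms (7 carbon, 2 nitrogen, 1 oxygen; one six-membered aromatic ring with 2 hetero atoms), on an aromatic carbon. For the measured compounds named here, no step between two measured compounds is available to calibrate this change, so the expectation rests on the two values alone and on the change itself. A modest gain in solubility is expected rather than a loss, though the size is uncertain and could fall within the usual scatter. The change is expected to amount to a 2.7-fold higher number from compound 2 to compound 3 (0.44 log units; beyond the scatter). Compound 3 is estimated at 30000 nM, between 8000 nM and 150000 nM.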

Compound 3, solubility: 110000 nM
Estimate against measurement, compound 3: 3.7-fold (0.56 log units) below; measured number inside the range.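

In this assay, the ring with 1 hetero atom in place of the ring with 2 hetero atoms, on an aromatic carbon opposite the ring nitrogen, gives a 10-fold higher number from compound 2 to compound 3 (1.00 log units; beyond the scatter), which gives this change at this place its first measured size. Among the compounds shown here, a second change, isopropyl in place of cyclobutyl on an aromatic nitrogen, gives an at least 9.0-fold lower number from compound 1 to compound 3 (0.95 log units; beyond the scatter), and this is the first step to show what that group on the aromatic nitrogen does to the number. Compound 1 stands at a limit, not at a number, so this second step has no upper end: the limit of > 1000000 nM in this assay, at which 1 of the 3 values shown sits.

The compounds shown leave open whether the first change gives a step of the same size with cyclobutyl on the aromatic nitrogen. Also open, on these data alone, is how a longer chain on that nitrogen, or a carboxylic acid in place of the dimethylamide, would read in this assay.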